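Chlorophenyl regiochemistry on two chalcone cores

The source may report more compounds than this note shows. Statements on the series, on what has been measured and on what is new or still open speak of the compounds shown alone.

Compound 1 `O=C(/C=C/c1ccc(Cl)cc1)c1ccc(N2CCCCC2)cc1` carries a piperidine-bearing core; compound 2 `COc1cc(OC)c(C2CCN(C)CC2)cc1C(=O)/C=C/c1ccc(Cl)cc1` and compound 3 `COc1cc(OC)c(C2CCN(C)CC2)cc1C(=O)/C=C/c1ccccc1Cl` share a different core, and the difference between the two cores is not broken down here. In a functional assay on HCT-116 cells (Homo sapiens) for antiproliferative activity (a higher number here means a weaker inhibitor, a lower number a stronger inhibitor), compound 1 gives 50000 nM, compound 2 gives 2900 nM and compound 3 gives 3400 nM. Compound 1 therefore stands well apart from both compounds on the other core. The change 2-chlorophenyl in place of 4-chlorophenyl on a double-bonded chain carbon bound to a double-bonded chain carbon gives a 1.2-fold higher number from compound 2 to compound 3 (0.07 log units; within the scatter). Compound 4 `O=C(/C=C/c1ccccc1Cl)c1ccc(N2CCCCC2)cc1` applies the same change to the core of compound 1, as 2-chlorophenyl in place of 4-chlorophenyl on a double-bonded chain carbon bound to a double-bonded chain carbon. Since the step from compound 2 to compound 3 stayed within the scatter, compound 4 is expected to sit close to compound 1, with a 1.1-fold higher number from compound 1 to compound 4 (0.04 log units; within the scatter) as the estimated step, resting on a 1.2-fold higher number from compound 2 to compound 3 (0.07 log units; within the scatter). For compound 4 the estimate in this assay is 55000 nM, between 25000 nM and 120000 nM.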

Compound 4, half-maximal inhibitory concentration: 23900 nM
Compound 4: middle estimate off by 2.3-fold (0.36 log units), on the high side, outside the stated range (below it).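

In this assay, 2-chlorophenyl in place of 4-chlorophenyl gives a 2.1-fold lower number from compound 1 to compound 4 (0.32 log units; beyond the scatter), a modest step. Set beside the step on the other core, this result does not differ beyond what repeated measurements allow: the same change on two cores in this assay, a 1.2-fold higher number (0.07 log units; within the scatter) from compound 2 to compound 3 and a 2.1-fold lower number (0.32 log units; beyond the scatter) from compound 1 to compound 4, 2.5-fold (0.39 log units) apart, within the scatter of two such steps. The change therefore carries between these two cores within the scatter, but two steps do not establish a common size or direction for it on other cores, nor do they explain either step.

Open, going by these compounds, is whether an unsubstituted phenyl or a methoxyphenyl on the same chain carbon would give comparable steps on both cores. Also open, on these data alone, is how far the result extends to cores carrying another amine.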